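A Trifluoromethyl Added to a Diaryl Urea Pyrazole

The source may report more compounds than this note shows. Statements on the series, on what has been measured and on what is new or still open speak of the compounds shown alone.

Compound 1: `COc1cc(Cl)cc(-c2nn(-c3cccc(NC(=O)Nc4cccc(C(F)(F)F)c4)c3)cc2-c2ccncc2)c1` — 95%
Compound 2: `COc1cc(Cl)cc(-c2nn(-c3cccc(NC(=O)Nc4ccc(Cl)c(C(F)(F)F)c4)c3)cc2-c2ccncc2)c1` — 94%

This account follows a single change made to compound 1. In a functional assay on Malme-3M cells (Homo sapiens) for inhibition, read by sulforhodamine B assay, with a stated time of 48 h, tested at 0.01 uM (on this read-out higher numbers stand for a weaker effect at the one concentration tested and lower numbers for a stronger effect), compound 1 gives 95%, and compound 2 gives 94%; the two numbers stand alongside one another, since the step of a number 1 percentage points lower from compound 1 to compound 2 (within the scatter) lies within the scatter. For the measured compounds named here, there is no measured compound whose number lies beyond the scatter from compound 1.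

Compound 3 is `COc1cc(Cl)cc(-c2nn(-c3cccc(NC(=O)Nc4cc(C(F)(F)F)cc(C(F)(F)F)c4)c3)cc2-c2ccncc2)c1`. It differs from compound 1 as follows: trifluoromethyl in place of hydrogen on an aromatic carbon. The entering group sits on an aromatic carbon of a six-membered aromatic ring of carbon only, meta to a trifluoromethyl group already present.

Going by the values given here, the only measured step that bears on this change is the one from compound 1 to compound 2, where a small group joined the same ring and the number moved by a number 1 percentage points lower from compound 1 to compound 2 (within the scatter), within the scatter. On that basis no movement beyond the scatter is expected in this assay, and the expected step is a number 2 percentage points lower from compound 1 to compound 3 (within the scatter). Compound 3 is therefore estimated at 93%, with a range from 80% to 104%.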

Compound 3, a percentage reported as activity, at one concentration (the size of the read-out at that concentration, not a potency): 92%
Estimate against measurement, compound 3: 1 percentage points above; the measured number falls inside the stated range.
By their numbers in this assay, from the lowest: compounds 3, 2 and 1 (each within the scatter of the next).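

In this assay the added group gives a number 3 percentage points lower from compound 1 to compound 3 (within the scatter) and so leaves compound 3 alongside compound 1, even with a second trifluoromethyl on an aromatic carbon, meta to the trifluoromethyl group already present. Compound 2 had shown this on the same ring only for the smaller chloro, with a number 1 percentage points lower from compound 1 to compound 2 (within the scatter) and now the same holds for an entering group of 4 heavy atoms, so among these three compounds neither substituent moves the number beyond the scatter at the one concentration tested. Nothing available here accounts for this absence of movement, and nothing shows whether it would hold at any other concentration.

It remains open whether an amine or a carboxylic acid on this same aromatic carbon would move the number beyond the scatter, since both added groups shown so far carry no hydrogen-bond donor or acceptor by the count for trifluoromethyl and no charge. Also open, on these data alone, is whether a nitrile in place of the existing trifluoromethyl group would leave the number alongside that of compound 1.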